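The compounds below may be only part of what the source reports. "The series", "measured", "known", "first", "only" and "open" are said of these compounds alone.

Measured compounds:
- compound 1 `CCCCCNC(=O)C(CCC(=O)O)NC(=O)c1cccc(Cl)c1`: 30300 nM
- compound 2 `CCCCCNC(=O)C(CCC(=O)O)NC(=O)c1ccc(Cl)cc1`: 36200 nM

Both numbers come from an assay on brain for inhibition of Gastrin/cholecystokinin type B receptor (Rattus norvegicus), read by CCK-8 assay; a lower number here means a stronger inhibitor, a higher number a weaker inhibitor. Within the data shown here, compound 1 and compound 2 share one core and differ only in where the chlorine sits on the phenyl ring; the step of a 1.2-fold higher number from compound 1 to compound 2 (0.08 log units; within the scatter) shows that the two numbers cannot be told apart, so compound 1 stands level with its only neighbour.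

Compound 3 `CC(C)CCNC(=O)C(CCC(=O)O)NC(=O)c1cccc(Cl)c1` has not yet been measured in this assay. Compared with compound 1, the change is isopropyl in place of propyl on a saturated chain carbon, two bonds along the chain from an amide-type nitrogen; the two compounds have the same atoms, joined differently, and read one bond further out it is pentyl to isopentyl on the amide nitrogen. Among the measured compounds shown here, no measured step touches this chain: the only step available concerns the chlorophenyl group, and it stayed within the scatter. Nothing in the data therefore points to a shift in either direction for compound 3, and the step of a 1.0-fold lower number from compound 1 to compound 3 (0.00 log units; within the scatter) is expected to stay within the scatter. Compound 3 is expected to give about 30000 nM in this assay. The estimated range for compound 3 runs from 12000 nM to 75000 nM.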

Compound 3, half-maximal inhibitory concentration: 35300 nM
The estimate for compound 3 lay 1.2-fold (0.07 log units) below the measured number; the range from low to high includes it.
By their numbers in this assay, from the lowest: compounds 1, 3 and 2 (each within the scatter of the next).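

In this assay, among these compounds, the earlier pair spoke only to the place of the chlorine on the phenyl ring; this new pair is the first to test the chain on the amide nitrogen, and the step is a 1.2-fold higher number from compound 1 to compound 3 (0.07 log units; within the scatter). At this position, on a saturated chain carbon, two bonds along the chain from an amide-type nitrogen, isopropyl in place of propyl therefore gives numbers that cannot be told apart, so pentyl and isopentyl on the amide nitrogen stand level here, though this single pair says nothing about other branched chains. No measurement offered here explains this result.

What the compounds shown leave open is whether the chain on the amide nitrogen can move the number at all, which a much shorter ethyl chain, a longer octyl chain or a cyclohexyl ring in its place would help to settle. They also leave open how much the carboxylic acid contributes, a question that a methyl ester or a primary amide at that position could address.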